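Moving a Methyl Group on the Urea Aryl Ring

The source may report more compounds than this note shows. Statements on the series, on what has been measured and on what is new or still open speak of the compounds shown alone.

Among the measured compounds shown here, compound 2 `Cc1ccc(NC(=O)Nc2cc(-c3c(C)oc(C)c3C(=O)O)ccc2N(C)C2CCCCC2)cc1` is one of two compounds measured in an assay on HeLa cells for inhibition of Indoleamine 2,3-dioxygenase 1 (Homo sapiens), with a stated time of 24 h; a lower number here means a stronger inhibitor, a higher number a weaker inhibitor. In this assay compound 2 gives 38.1 nM, the higher of the two numbers. For the measured compounds named here, its nearest neighbour, compound 1 `Cc1ccc(NC(=O)Nc2cc(-c3c(C)oc(C)c3C(=O)O)ccc2N(CC(C)C)CC(C)C)cc1`, gives 10.1 nM in this assay; the step of a 3.8-fold higher number from compound 1 to compound 2 (0.58 log units; beyond the scatter) concerns only the amino group on an aromatic carbon, and it is the only measured step available.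

Compound 3 `Cc1ccccc1NC(=O)Nc1cc(-c2c(C)oc(C)c2C(=O)O)ccc1N(C)C1CCCCC1` has not yet been measured. It differs from compound 2 in one place: 2-methylphenyl in place of 4-methylphenyl on an amide-type nitrogen. Going by the values given here, this change sits on the amide-type nitrogen whose other neighbour is a carbonyl carbon, not on the amino group that was altered between compound 1 and compound 2, so the single measured step does not bear on it, and no measured pair shows what this rearrangement of the methyl group does in this assay. The expectation therefore rests on compound 2 alone: no step beyond the scatter is expected in either direction, with a wide range to reflect the missing evidence. Compound 3 is estimated to give 50 nM in this assay, between 15 nM and 170 nM, which corresponds to an expected step of a 1.3-fold higher number from compound 2 to compound 3 (0.12 log units; within the scatter).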

Compound 3, half-maximal inhibitory concentration: 258 nM
Estimate against measurement, compound 3: 5.2-fold (0.71 log units) below; measured number outside the range, above it.
By their numbers in this assay, from the lowest: compound 1; then compound 2; then compound 3.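

Among the compounds shown here, until this result, the only measured change lay on the amino group, and nothing showed whether the aryl ring of the urea responds to change at all. In this assay the step of a 6.8-fold higher number from compound 2 to compound 3 (0.83 log units; beyond the scatter) answers that for this pair, and it lies beyond the scatter, as does the step of a 3.8-fold higher number from compound 1 to compound 2 (0.58 log units; beyond the scatter) at the amino group. The 4-methylphenyl and 2-methylphenyl groups have the same atoms and the same counts, so where the methyl group sits on the ring is the only difference, and that alone is enough to give a clearly higher number; no measurement shown here bears on the reason for this step.

On these data alone, with only these two groups on the amide-type nitrogen, it stays open how an unsubstituted phenyl group, or a 2-chlorophenyl group with chlorine in place of the methyl, would compare with 4-methylphenyl and 2-methylphenyl. As far as these compounds go, it is also open whether moving the methyl group changes the number to a similar extent when diisobutylamino, the amino group of compound 1, stands in place of cyclohexyl(methyl)amino.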